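This account rests on a few compounds, and the source may have more. Where it says the series, first, only, none or still open, it means among the compounds named here.

Measured in an ADME assay on L1210 cells (Mus musculus) for cytotoxicity, with a stated time of 48 h; on this read-out higher numbers stand for weaker inhibition and lower numbers for stronger inhibition:
- Compound 1 `CC1=CCC[C@](C)(CC/C(C)=C/CC2=C(O)C(=O)C=C(N[C@H](C(=O)O)[C@@H](C)O)C2=O)[C@@H]1C`: > 10 ug/mL, a limit of the assay and not a number
- Compound 2 `C=C1[C@H](C)CCC[C@]1(C)CC/C(C)=C/CC1=C(O)C(=O)C=C(N[C@@H](C(=O)O)C(C)C)C1=O`: 3.4 ug/mL
- Compound 3 `C=C1[C@H](C)CCC[C@]1(C)CC/C(C)=C/CC1=C(O)C(=O)C=C(N[C@@H](C(=O)O)[C@H](C)O)C1=O`: 4.6 ug/mL

Compound 3 stands at 4.6 ug/mL in this assay, and compound 2 lies within the scatter of it at 3.4 ug/mL. For the measured compounds named here, only one step between measured compounds is available, a 1.4-fold higher number from compound 2 to compound 3 (0.13 log units; within the scatter). Going by the values given here, no measured step connects compound 1 with the other two, so its limit gives no step size.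

Compound 4 `C=C1[C@H](C)CCC[C@]1(C)CC/C(C)=C/CC1=C(O)C(=O)C=C(N[C@H](C(=O)O)[C@@H](C)O)C1=O` has not yet been measured. Its relation to compound 3 is the two compounds have the same atoms and bonds and differ only in configuration as drawn: 2 of 5 stereo elements differ; a stereocentre at a saturated chain carbon is drawn R in compound 3 and S in compound 4; a stereocentre at a saturated chain carbon is drawn S in compound 3 and R in compound 4. The two compounds have the same atoms and bonds, so nothing leaves or enters, and only the configuration as drawn differs.

Among the compounds with values here, no measured step changes configuration alone. Within the data shown here, the one available step exchanges a group, and it bears on this change only indirectly. It shows no shift beyond the scatter, but it cannot show what inverting the two stereocentres does. No step beyond the scatter is therefore expected in this assay, and no direction can be assigned, although the uncertainty is wide. The expected step is a 1.1-fold higher number from compound 3 to compound 4 (0.04 log units; within the scatter). For compound 4 the estimated value is 5 ug/mL, with an expected range from 2.5 ug/mL to 11 ug/mL.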

Compound 4, half-maximal inhibitory concentration: > 10 ug/mL
Compound 4 gave a limit, no number; the forecaster's own chance of this, stated with the estimate: 20%; middle value at least 2.0-fold (0.30 log units) from the limit.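

In this assay, for the compounds shown here, there is an at least 2.1-fold higher number from compound 3 to compound 4 (0.33 log units; beyond the scatter), whereas the earlier exchange of isopropyl for 1-hydroxyethyl gave only a 1.4-fold higher number from compound 2 to compound 3 (0.13 log units; within the scatter), so this is the first shift beyond the scatter, and it comes from inverting the two stereocentres on saturated chain carbons alone: the fact that compounds 3 and 4 differ only in the configuration as drawn. Read against the isopropyl-bearing compound, 1-carboxy-2-hydroxypropyl in place of 1-carboxy-2-methylpropyl on an amine nitrogen gives an at least 2.9-fold higher number from compound 2 to compound 4 (0.46 log units; beyond the scatter), so this exchange of groups stays within the scatter when it leads to compound 3 but not when it leads to compound 4. Both of these steps give only a smallest size, and the step between compound 1 and compound 4 cannot be read, as each of those compounds gives a limit of the assay and not a number: the limit of > 10 ug/mL in this assay, at which 2 of the 4 values shown sit.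

The compounds shown leave open which of the two stereocentres carries the step, as both change together in compounds 3 and 4. They also leave open whether a methyl ester or an amide in place of the carboxylic acid would show the same dependence on configuration.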